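Fluoro for Chloro on the Benzyl Ring of Compound 2

A few compounds are considered here, and "the series" means these few. Any claim that something is new, unique, unknown or untested is made for them only; others in the source may bear on it.

Measured so far in an assay on isolated protein for inhibition of aldehyde dehydrogenase 1A1 (Homo sapiens), read by spectrophotometry, tested at 10 uM; on this read-out higher numbers stand for more inhibition at the one concentration tested (going by the name of the read-out) and lower numbers for less inhibition:
Compound 1 `O=C(C1CC1)N1CCN(Cc2nc3ccccc3n2Cc2ccccc2)CC1` gives 23.9%.
Compound 2 `O=C(C1CC1)N1CCN(Cc2nc3ccccc3n2Cc2cccc(Cl)c2)CC1` gives 71.6%.

Among the measured compounds shown here, compound 2 stands highest of the two numbers; its only neighbour is compound 1, and the step of a number 47.7 percentage points higher from compound 1 to compound 2 (beyond the scatter) lies beyond the scatter and is large. Compound 3 `O=C(C1CC1)N1CCN(Cc2nc3ccccc3n2Cc2cccc(F)c2)CC1` has not yet been measured. It differs from compound 2 in one place: fluoro in place of chloro on an aromatic carbon. For the measured compounds named here, one measured step bears on this change, a number 47.7 percentage points higher from compound 1 to compound 2 (beyond the scatter), which shows how far the read-out moved when chloro replaced hydrogen at this position. Fluoro is neither hydrogen nor chloro, and no measured compound carries it, so the outcome is open. A step downward from compound 2 is expected, though smaller than the whole gap back to compound 1. Compound 3 is therefore estimated at 45%, between 22% and 68%, an expected step of a number 26.6 percentage points lower from compound 2 to compound 3 (beyond the scatter).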

Compound 3, a percentage reported as inhibition, at one concentration (the size of the read-out at that concentration, not a potency): 27.2%
Beside the measured number, compound 3's estimate is 17.8 percentage points above it, and the stated range covers the measured number.
By their numbers in this assay, from the lowest: compounds 1 and 3 (each within the scatter of the next); then compound 2.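

The gain seen with chloro in this assay does not extend to every halogen at this position: fluoro in place of chloro gives a number 44.4 percentage points lower from compound 2 to compound 3 (beyond the scatter), which undoes nearly all of that gain. Compared with the unsubstituted benzyl group, fluoro gives a number 3.3 percentage points higher from compound 1 to compound 3 (within the scatter), so on this read-out the 3-fluorobenzyl group cannot be told apart from plain benzyl. The identity of the halogen therefore matters here, not just the presence of one, but no measurement at hand explains the difference between chloro and fluoro.

On these data alone, whether bromo, methyl or methoxy in place of chloro would hold the level of compound 2 remains open. So does what chloro would do on another carbon of the same ring.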